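One Chloro Added to Compound 3: An Expected Step

The source may report more compounds than this note shows. Statements on the series, on what has been measured and on what is new or still open speak of the compounds shown alone.

Of the compounds shown here, three of this study have been tested in a functional assay on A549 cells (Homo sapiens) for cytotoxicity, read by MTT assay, with a stated time of 72 h; on this read-out lower numbers stand for stronger inhibition and higher numbers for weaker inhibition. Compound 1 `CNC(=O)c1cc(Oc2ccc(NC(=O)c3nn(-c4ccccc4OC(F)(F)F)c(=O)cc3C)cc2F)ccn1` does not give a number there but only the limit of the assay, > 40000 nM. Compound 2 `Cc1ccc(-n2nc(C(=O)Nc3ccc(Oc4ncnc5sccc45)cc3)c(C)cc2=O)cc1` likewise returns only the limit, > 40000 nM. Compounds 1 and 2 thus both sit at the limit of > 40000 nM in this assay, at which 2 of the 3 values shown sit. Among the compounds with values here, compound 3 `O=C(Nc1ccc(Oc2ncnc3ccsc23)c(F)c1)c1nn(-c2ccc(F)cc2)ccc1=O` is the single compound with a measured number, giving 8230 nM in this assay, and so it stands alone among the three as the only one whose inhibition could be quantified.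

Compound 4 `O=C(Nc1ccc(Oc2ncnc3ccsc23)c(F)c1)c1nn(-c2ccc(F)c(Cl)c2)ccc1=O` has not yet been measured. It differs from compound 3 by chloro in place of hydrogen on an aromatic carbon, so that the 4-fluorophenyl of compound 3 becomes a 3-chloro-4-fluorophenyl, the new chloro sitting ortho to the fluoro group and meta to a large group. Within the data shown here, no pair of measured compounds differs in one place, so the data hold no measured step that shows what such a substitution does on this core. The step is expected to be modest and to lean toward stronger inhibition, roughly a 1.6-fold lower number from compound 3 to compound 4 (0.22 log units; within the scatter) in this assay, not clearly beyond the usual scatter. Compound 4 is therefore estimated to give about 5000 nM in this assay, with a plausible range from 1500 nM to 16000 nM.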

Compound 4, half-maximal inhibitory concentration: 9650 nM
Compound 4: the middle estimate sits 1.9-fold (0.29 log units) below what was measured; low and high end bracket the measured number.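

In this assay, within the data shown here, the step gives the first measured reading of any single change on this core: chloro in place of hydrogen on an aromatic carbon, ortho to the fluoro group and meta to a large group, turning the 4-fluorophenyl into a 3-chloro-4-fluorophenyl, gives a 1.2-fold higher number from compound 3 to compound 4 (0.07 log units; within the scatter). The two compounds therefore cannot be told apart in this assay, and at this one position, on this one core, the added chlorine leaves the read-out where it was within the usual scatter. Compound 3 and compound 4 both return real numbers rather than a limit, which makes this step readable, whereas the other two values shown are limits and offer no such reading: the limit of > 40000 nM in this assay, at which 2 of the 4 values shown sit.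

What the compounds shown leave open is whether this flat result belongs to the position or only to chloro, since a methoxy group, an amine or a carboxylic acid on the same carbon could read quite differently. From the compounds shown here alone, it is also open whether the same chloro would give the same result on another carbon of that ring, or whether replacing the fluoro group would shift the number.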